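Methoxy for Carboxy on the Shared Core

The source may hold more compounds than are shown below. What is called first, only, known or untested is meant among the compounds shown, and "the series" means these compounds.

Compound 1 `CN(C)c1ccc(/C=C/C(=O)c2ccc[nH]2)cc1` in an assay for inhibition of cytochrome P450 1A1 (Homo sapiens), read by fluorescence, using microsomes, with a stated time of 10 min (a higher number here means a weaker inhibitor, a lower number a stronger inhibitor), gives only a limit, > 20000 nM.
Compound 2 `O=C(O)c1ccc(/C=C/C(=O)c2ccc[nH]2)cc1` in this assay also gives only a limit, > 20000 nM.

Both measured values share (the limit of > 20000 nM in this assay, at which 2 of the 2 values shown sit); compound 2 thus stands at a limit, not at a number. For the measured compounds named here, the one measured step, a step that the two limits leave unreadable from compound 1 to compound 2, is unreadable for the same reason. Compound 3 `COc1ccc(/C=C/C(=O)c2ccc[nH]2)cc1` differs from compound 2 by methoxy in place of carboxy on an aromatic carbon. Going by the values given here, no measured step bears readably on this change, so the expected step that the limit leaves unreadable from compound 2 to compound 3 is set to none beyond the scatter. Compound 3 is therefore estimated at 30000 nM, between 8000 nM and 100000 nM, and is expected most likely to be reported again as a limit.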

Compound 3, half-maximal inhibitory concentration: > 20000 nM
Compound 3: no number, only a limit; the forecaster's own chance of this, stated with the estimate: 70%; the middle value does not contradict the limit.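

Compound 3, like compound 1 and compound 2, gives only a limit, so no step among these three compounds can be read: the limit of > 20000 nM in this assay, at which 3 of the 3 values shown sit.

The compounds shown leave open how dimethylamino, carboxy and methoxy on the shared core truly compare in this assay.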